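This account rests on a few compounds, and the source may have more. Where it says the series, first, only, none or still open, it means among the compounds named here.

Compound 1 `COC(=O)C1=C(C)N=C(C)/C(=C(\O)OC)C1c1cccc([N+](C)(C)C)c1` gives 50100 nM. Compound 2 `COC(=O)C1=C(C)N=C(C)/C(=C(\O)OC)C1c1ccc(I)cc1` gives 22900 nM. Compound 3 `COC(=O)C1=C(C)N=C(C)/C(=C(\O)OC)C1c1cc(OC)c(OC)cc1OC` gives 1000000 nM.

In a functional assay (muscle tissue) with Cavia porcellus as the target (on this read-out higher numbers stand for an effect only at larger amounts of compound and lower numbers for an effect already at smaller amounts), compound 2 stands at the lowest of the three numbers; compound 1 lies above it by a margin beyond the scatter, and compound 3 lies far above it. Compound 4 `COC(=O)C1=C(C)N=C(C)/C(=C(\O)OC)C1c1ccc(Br)cc1` is the compound not yet measured. It differs from compound 2 by bromo in place of iodo on an aromatic carbon. Among the compounds with values here, no pair among the measured compounds shares this change, so nothing measured here shows its size. The change is small, and compound 4 is expected to stay close to compound 2 with a step of a 1.3-fold higher number from compound 2 to compound 4 (0.12 log units; within the scatter) that lies within the scatter. Compound 4 is estimated at 30000 nM, between 12000 nM and 80000 nM.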

Compound 4, half-maximal effective concentration: 540 nM
The estimate for compound 4 lay 56-fold (1.74 log units) above the measured number; measured number outside the range, below it.
By their numbers in this assay, from the lowest: compound 4; then compound 2; then compound 1; then compound 3.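

Replacing iodo with bromo on this aromatic carbon exchanges one heavy atom for one, with no change in rings, hydrogen-bond donors, hydrogen-bond acceptors or net charge, yet in this assay it gives a 42-fold lower number from compound 2 to compound 4 (1.63 log units; beyond the scatter) in the number. Within the data shown here, this position is therefore highly sensitive to which halogen it carries, something the earlier compounds, with no pair differing in one place, could not show. Nothing available here explains the size of this step.

The compounds shown leave open how chloro, fluoro or a methyl group would read at this position. They also leave open whether an unsubstituted phenyl would lie nearer compound 2 or compound 4.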